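A few compounds are considered here, and "the series" means these few. Any claim that something is new, unique, unknown or untested is made for them only; others in the source may bear on it.

Of the compounds shown here, two built on the same core have been read so far in an in vitro ADME assay on microsomes from liver (Homo sapiens) for metabolic stability; on this read-out lower numbers stand for slow clearance and higher numbers for fast clearance. Compound 1 `CS(=O)(=O)c1cc(Cl)c(NC(=O)N2CCN3C(=O)N([C@H]4C[C@@H]4c4ccccc4)C(=O)[C@@H]3C2)c(Cl)c1` gives 58000 mL.min-1.g-1 and compound 2 `O=C(Nc1ccnn1-c1cccc(Cl)c1)N1CCN2C(=O)N([C@H]3C[C@@H]3c3ccccc3)C(=O)[C@@H]2C1` gives 62000 mL.min-1.g-1. These two numbers lie within the scatter of each other, so compound 2 stands level with compound 1. Compound 3 `O=C(Nc1ccnn1-c1cccc(F)c1)N1CCN2C(=O)N([C@H]3C[C@@H]3c3ccccc3)C(=O)[C@@H]2C1` departs from compound 2 in one place: fluoro in place of chloro on an aromatic carbon, meta to a large group, so that 3-chlorophenyl becomes 3-fluorophenyl. Within the data shown here, no measured pair shows this change, so the data offer no step to borrow, and compound 2 at 62000 mL.min-1.g-1 is the only anchor for the expectation. In this assay the expected step of a 1.2-fold lower number from compound 2 to compound 3 (0.08 log units; within the scatter) is small, slightly downward and within the scatter. For compound 3 the estimated value is 52000 mL.min-1.g-1, with an expected range of 30000 mL.min-1.g-1 to 85000 mL.min-1.g-1.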

Compound 3, intrinsic clearance in microsomes: 45000 mL.min-1.g-1
Compound 3: the middle estimate sits 1.2-fold (0.06 log units) above what was measured; measured number inside the range.
By their numbers in this assay, from the lowest: compounds 3, 1 and 2 (each within the scatter of the next).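

In this assay the exchange of chloro for fluoro on this aromatic carbon, meta to a large group, gives a 1.4-fold lower number from compound 2 to compound 3 (0.14 log units; within the scatter) and so stays within the scatter. This is the first pair shown that differs in one place, and it shows that 3-chlorophenyl and 3-fluorophenyl cannot be told apart on this read-out. Nothing measured here speaks to what lies behind this small step.

As far as these compounds go, whether a group of another kind at this place, such as a methoxy group, an amine or a carboxylic acid, would give a step beyond the scatter remains open. Also open, from the compounds shown here alone, is whether the same exchange of chloro for fluoro would read alike at another place on the aromatic ring or with a different group on the shared core.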